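Methoxycarbonyl in Place of Chloro, Tested a Second Time

The compounds below may be only part of what the source reports. "The series", "measured", "known", "first", "only" and "open" are said of these compounds alone.

Compound 1 `CCCCCCCCc1ccc(OCC(=O)Cn2nnc(-c3cccc(Cl)c3)n2)cc1` and compound 2 `CCCCCCCCc1ccc(OCC(=O)Cn2nnc(-c3cccc(C(=O)OC)c3)n2)cc1` share one core and differ in a single place: methoxycarbonyl in place of chloro on an aromatic carbon. In an ADME assay on S9 fraction from liver (Rattus norvegicus) for metabolic stability, read by LC-MS, using NADPH, with a stated time of 30 min (on this read-out lower numbers stand for a less stable compound and higher numbers for a more stable compound), compound 1 gives 69%, and compound 2 gives 19%, a step of a number 50 percentage points lower from compound 1 to compound 2 (beyond the scatter). Compound 3 `CCCCCCCCc1ccc(OC(C)C(=O)Cn2nnc(-c3ccc(Cl)cc3)n2)cc1` rests on a core whose difference from that of compound 1 is not broken down here; in this assay compound 3 gives 72%. Compound 4 `CCCCCCCCc1ccc(OC(C)C(=O)Cn2nnc(-c3ccc(C(=O)OC)cc3)n2)cc1` is not yet measured and differs from compound 3 by methoxycarbonyl in place of chloro on an aromatic carbon. This is the same kind of change as that from compound 1 to compound 2, though the surroundings differ: there the group sits meta to a large group, here para to a large group. Because the step of a number 50 percentage points lower from compound 1 to compound 2 (beyond the scatter) was large, compound 4 is expected to show a number 47 percentage points lower from compound 3 to compound 4 (beyond the scatter). Compound 4 is therefore estimated at 25%, with a range from 10% to 45%.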

Compound 4, percent of the compound remaining: 62%
Beside the measured number, compound 4's estimate is 37 percentage points below it; measured number outside the range, above it.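

In this assay, among the compounds shown here, methoxycarbonyl in place of chloro on an aromatic carbon gives a number 10 percentage points lower from compound 3 to compound 4 (within the scatter), so on this core the change leaves no step that stands clear of the scatter. The size of the change does not carry from the core of compound 1 to the core of compound 3: the same change on two cores in this assay, a number 50 percentage points lower (beyond the scatter) from compound 1 to compound 2 and a number 10 percentage points lower (within the scatter) from compound 3 to compound 4, 40 percentage points apart, beyond the scatter of two such steps. These two pairs do not show why the steps part, since the place of the group on the ring and the rest of the core both differ between them.

The compounds shown leave open how a carboxylic acid or an amide in place of chloro would read on either core. They also leave open whether a shorter chain in place of the octyl chain would alter either step.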